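The compounds below may be only part of what the source reports. "The series", "measured", "known", "first", "only" and "open" are said of these compounds alone.

Measured compounds:
compound 1 `CC(C)(C)c1nc(-c2ccc[nH]2)c2cc(C(N)=O)c(N)nc2n1`, 130000 nM
compound 2 `N#Cc1c(N)nc2nc(C3CCCCC3)ncc2c1N`, 81000 nM
compound 3 `CCCCc1nc(C(C)(C)C)nc2nc(N)c(C#N)c(N)c12`, 6000 nM

In a physicochemical assay for solubility, in phosphate buffer, with a stated time of 18 h (a lower number here means a less soluble compound, a higher number a more soluble compound), compound 3 has the lowest of the three numbers; compound 2 sits a good way higher, beyond the scatter, and compound 1 is furthest from it, also beyond the scatter. Compound 4 `CC(C)(C)c1nc(-c2nc(CO)cs2)c2c(N)c(C#N)c(N)nc2n1` has not yet been measured in this assay. It differs from compound 3 in one place: 4-(hydroxymethyl)-1,3-thiazol-2-yl in place of butyl on an aromatic carbon. For the measured compounds named here, no step between measured compounds isolates this kind of change, so its size can only be guessed. Compound 4 is expected to move upward from compound 3 by a 3.3-fold higher number from compound 3 to compound 4 (0.52 log units; beyond the scatter), a step beyond the scatter but not reaching the numbers of compound 1 or compound 2. The estimate for compound 4 in this assay is 20000 nM, within a range of 5000 nM to 80000 nM.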

Compound 4, solubility: < 1000 nM
Compound 4 was reported as a limit; the forecaster's own chance of this, stated with the estimate: 5%; middle value at least 20-fold (1.30 log units) away from the limit.
By their numbers in this assay, from the lowest: compound 3; then compounds 2 and 1 (each within the scatter of the next). At a limit, below all of these: compound 4.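

In this assay, putting 4-(hydroxymethyl)-1,3-thiazol-2-yl in place of butyl on this aromatic carbon gives an at least 6.0-fold lower number from compound 3 to compound 4 (0.77 log units; beyond the scatter), the first single-place step shown at this position. A larger group that brings a ring, a hydrogen-bond donor and hydrogen-bond acceptors therefore gives no higher number here. The value of compound 4 is a limit, not a number: the limit of < 1000 nM in this assay, at which 1 of the 4 values shown sits.

The compounds shown leave open whether the step belongs to the thiazole ring or to its hydroxymethyl. As far as these compounds go, how an amine or a carboxylic acid on this carbon would read in this assay also remains open.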